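This account rests on a few compounds, and the source may have more. Where it says the series, first, only, none or still open, it means among the compounds named here.

Measured so far in a functional assay on CHO cells for agonist activity at Free fatty acid receptor 1 (Homo sapiens), read by a luciferase reporter; a higher number here means a larger maximal response, a lower number a smaller maximal response:
- compound 1 `Cc1nc(-c2ccc(C(F)(F)F)cc2)sc1CNc1ccc(CCC(=O)O)cc1` — 108%
- compound 2 `O=C(O)CCCc1ccc(NCc2cccc(Oc3ccccc3)c2)cc1` — 59%
- compound 3 `Cc1nc(-c2ccc(C(F)(F)F)cc2)sc1CNc1ccc(OCC(=O)O)cc1` — 100%

Compound 2 stands lowest of the three in this assay; its gaps to compound 3 and to compound 1 both lie beyond the scatter. Among the measured compounds shown here, compound 1 and compound 3 share a core, and the only measured single-site step, a number 8 percentage points lower from compound 1 to compound 3 (within the scatter), concerns that core and not the side chain carried by compound 2.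

Compound 4 `CC(Cc1ccc(NCc2cccc(Oc3ccccc3)c2)cc1)C(=O)O` differs from compound 2 as follows: 1-carboxyethyl in place of 2-carboxyethyl on a saturated chain carbon bound to an aromatic carbon. For the measured compounds named here, no measured pair shows this particular change; the one measured step swaps a 2-carboxyethyl for a carboxymethoxy group and stays within the scatter, which gives no direction for a shift of the carboxylic acid along the chain. The expectation is therefore no step beyond the scatter, with wide uncertainty on either side.

For compound 4 in this assay the estimated value is 60%, with a range from 35% to 85%; the step this implies, a number 1 percentage points higher from compound 2 to compound 4 (within the scatter), is expected to stay within the scatter.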

Compound 4, largest response reached (reported as percent of maximum), in percent of the reference or control that the assay uses: 70%
Compound 4: the middle estimate sits 10 percentage points below what was measured; the range from low to high includes it.
By their numbers in this assay, from the lowest: compound 2; then compound 4; then compounds 3 and 1 (each within the scatter of the next).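

In this assay, among the compounds shown here, the side chain of compound 2 proves sensitive to a single change: 1-carboxyethyl in place of 2-carboxyethyl on a saturated chain carbon bound to an aromatic carbon gives a number 11 percentage points higher from compound 2 to compound 4 (beyond the scatter) as the first single-site step that lies beyond the scatter. The two groups have the same heavy atoms and the same counts, so rearranging the same atoms at this position is enough to produce a modest step in the maximal response. No supporting data bear on the origin of this step.

Going by these compounds, this reading rests on one pair, so whether 1-carboxyethyl gives a similar step on the core of compound 1 remains open. Also open, on these data alone, is how a longer chain, or an amide in place of the carboxylic acid, would read at this position.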